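The compounds below may be only part of what the source reports. "The series", "measured", "known", "first", "only" and "open" are said of these compounds alone.

Measured so far:
Compound 1, `COc1cccc(CNCCCNc2ccnc3cc(Oc4ccccc4)ccc23)c1O`, gives 14500 nM in a physicochemical assay for solubility, with a stated time of 18 h, at pH 7.4; a lower number here means a less soluble compound, a higher number a more soluble compound.
Compound 2, `COc1cccc(CNCCCNc2ccnc3cc(-c4ccc(F)cc4)ccc23)c1O`, gives 32000 nM in this assay.

Compound 2 stands highest of the two numbers in this assay; its nearest neighbour is compound 1, and the step of a 2.2-fold higher number from compound 1 to compound 2 (0.34 log units; beyond the scatter) lies beyond the scatter. Compound 3, `COc1cccc(CNCCCNc2ccnc3cc(-c4ccc(C(C)(C)C)cc4)ccc23)c1O`, is not yet measured. It differs from compound 2 in one place: tert-butyl in place of fluoro on an aromatic carbon. Within the data shown here, no measured step exchanges one group for another on this outer six-membered ring; the only step on record, a 2.2-fold higher number from compound 1 to compound 2 (0.34 log units; beyond the scatter), swaps phenoxy for 4-fluorophenyl, a change of a different kind, so it bears on compound 3 only loosely. With just two numbers, any expectation for compound 3 rests on thin ground and carries a wide range. The expectation for compound 3 is a modest drop in this assay, a 3.6-fold lower number from compound 2 to compound 3 (0.55 log units; beyond the scatter), though a result within the scatter of compound 2 would not be surprising. Compound 3 is therefore estimated at 9000 nM, within a range from 3000 nM to 27000 nM.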

Compound 3, solubility: 32000 nM
Beside the measured number, compound 3's estimate is 3.6-fold (0.55 log units) below it; measured number outside the range, above it.
By their numbers in this assay, from the lowest: compound 1; then compounds 2 and 3 (each within the scatter of the next).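

In this assay, among these compounds, the exchange of fluoro, with 1 heavy atom, for tert-butyl, with 4 heavy atoms, is the first change on record at this place on the six-membered aromatic ring of carbon only, and it reads no change at the digits printed from compound 2 to compound 3 (within the scatter). Among these compounds, then, a larger group at this place comes with no shift in the read-out, though this rests on a single pair in which neither group carries a hydrogen-bond donor, a hydrogen-bond acceptor or a net charge. The step of a 2.2-fold higher number from compound 1 to compound 3 (0.34 log units; beyond the scatter) matches a 2.2-fold higher number from compound 1 to compound 2 (0.34 log units; beyond the scatter), so the two phenyl-bearing compounds sit on the same side of the phenoxy compound, and nothing measured here explains either result.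

From the compounds shown here alone, what an amine or a carboxylic acid would give at this same place remains open, since both groups compared here lack donors, acceptors and charge. A longer chain in place of tert-butyl is also untested in the compounds shown, so it cannot be said whether the read-out stays level for groups beyond this pair.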